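Nitrophenyl Replaces Fluorophenyl on a Pyrimidine Ester Core

The source may report more compounds than this note shows. Statements on the series, on what has been measured and on what is new or still open speak of the compounds shown alone.

Measured compounds:
Compound 1 `CCOC(=O)c1cnc(-c2ccccc2)nc1NN1C(=O)C=C(C)C1=O`: 100 nM
Compound 2 `CCOC(=O)c1cnc(-c2ccncc2)nc1NN1C(=O)C=C(C)C1=O`: 6000 nM
Compound 3 `CCOC(=O)c1cnc(-c2ccc(F)cc2)nc1NN1C(=O)C=C(C)C1=O`: 700 nM

All three share one core and differ only in the aromatic group attached to it. In a functional assay on Jurkat cells for inhibition of nuclear factor NF-kappa-B complex (Homo sapiens) (a higher number here means a weaker inhibitor, a lower number a stronger inhibitor), compound 3 gives 700 nM, which places it second highest of the three numbers: compound 1 gives 100 nM and compound 2 gives 6000 nM.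

Compound 4 `CCOC(=O)c1cnc(-c2cccc([N+](=O)[O-])c2)nc1NN1C(=O)C=C(C)C1=O` is the next step from compound 3, with 3-nitrophenyl in place of 4-fluorophenyl on an aromatic carbon.

Among the measured compounds shown here, two measured steps bear on this. Adding fluoro to the phenyl ring gave a 7.0-fold higher number from compound 1 to compound 3 (0.85 log units; beyond the scatter), and exchanging phenyl for pyridin-4-yl gave a 60-fold higher number from compound 1 to compound 2 (1.78 log units; beyond the scatter); going back from pyridin-4-yl to 4-fluorophenyl gave an 8.6-fold lower number from compound 2 to compound 3 (0.93 log units; beyond the scatter). Every change so far away from the plain phenyl of compound 1 has raised the number, so a further change that brings in two hydrogen-bond acceptors is expected to raise it again, by a modest to large step.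

Compound 4 is therefore expected to show a 2.9-fold higher number from compound 3 to compound 4 (0.46 log units; beyond the scatter), with an estimated value of 2000 nM and a likely range from 500 nM to 8000 nM.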

Compound 4, half-maximal inhibitory concentration: 7000 nM
For compound 4 the middle estimate is 3.5-fold (0.54 log units) below the measured one, within the range that was stated.
By their numbers in this assay, from the lowest: compound 1; then compound 3; then compounds 2 and 4 (each within the scatter of the next).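

In this assay, the plain phenyl of compound 1 keeps the lowest number at this position between two ring nitrogen atoms: adding nitro to that ring gives a 70-fold higher number from compound 1 to compound 4 (1.85 log units; beyond the scatter), and 3-nitrophenyl in place of 4-fluorophenyl gives a 10-fold higher number from compound 3 to compound 4 (1.00 log units; beyond the scatter). A ring of carbon only can therefore land level with the pyridin-4-yl group, as a 1.2-fold higher number from compound 2 to compound 4 (0.07 log units; within the scatter) shows, so a ring nitrogen is not needed to reach that level here. Nothing available explains why any of these groups raises the number.

Compound 3 and compound 4 differ both in the group and in where it sits on the phenyl ring, so the contribution of each remains unsettled. Also open, going by these compounds, is whether an amine or a methoxy group on that ring would stay close to compound 1 or rise towards compound 4.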